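Carbamate cap variation and cytotoxicity on L929 cells

A few compounds are considered here, and "the series" means these few. Any claim that something is new, unique, unknown or untested is made for them only; others in the source may bear on it.

Measured compounds:
compound 1 `CC(C)C[C@H](NC(=O)OCC1CCC(F)(F)CC1)C(=O)N[C@H](C=O)C[C@@H]1CCNC1=O` — > 100000 nM
compound 2 `CCCCC1CCC(OC(=O)N[C@@H](CC(C)C)C(=O)N[C@@H](C[C@@H]2CCNC2=O)C(O)S(=O)(=O)O)CC1` — 59100 nM
compound 3 `CCCC1CCC(OC(=O)N[C@@H](CC(C)C)C(=O)N[C@@H](C[C@@H]2CCNC2=O)C(O)S(=O)(=O)O)CC1` — > 100000 nM

In a toxicity assay on L929 cells (Mus musculus) for cytotoxicity (a lower number here means that less compound is tolerated, a higher number that more compound is tolerated), compound 1 reaches only the limit of the assay, > 100000 nM, and no number. Compound 2 gives 59100 nM. Compound 3 likewise sits at a limit, > 100000 nM, rather than at a number. For the measured compounds named here, the one measured step, an at least 1.6-fold higher number from compound 2 to compound 3 (0.22 log units; that floor lies within the scatter), cannot be sized beyond its floor, since (the limit of > 100000 nM in this assay, at which 2 of the 3 values shown sit).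

Compound 4 `CC(C)C[C@H](NC(=O)OCC1CCC(F)(F)CC1)C(=O)N[C@@H](C[C@@H]1CCNC1=O)C(O)S(=O)(=O)O` is not yet measured. It differs from compound 3 as follows: (4,4-difluorocyclohexyl)methyl in place of 4-propylcyclohexyl on an oxygen next to a carbonyl group. Going by the values given here, no measured step covers this change, and no step covers the exchange of a propyl for two fluorines on the ring. Among the compounds with values here, the only guidance is that two of the three values in this assay lie at the limit, and compound 3 is one of them. Compound 4 is therefore expected to stay at or near that limit, with a number no higher from compound 3 to compound 4 (the limit leaves the size open) expected. The estimate for compound 4 in this assay is 100000 nM, with a range from 40000 nM to 250000 nM.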

Compound 4, half-maximal cytotoxic concentration: > 100000 nM
Compound 4 was reported as a limit; the forecaster's own chance of this, stated with the estimate: 60%; the middle value sits exactly at the limit.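

In this assay compound 4 reaches only a limit, > 100000 nM, and no number. For the compounds shown here, this extends the limit to a second kind of group on an oxygen next to a carbonyl group, (4,4-difluorocyclohexyl)methyl as well as 4-propylcyclohexyl, and the one readable step, an at least 1.6-fold higher number from compound 2 to compound 4 (0.22 log units; that floor lies within the scatter), has a floor that does not get past the scatter. The steps from compound 3 and from compound 1 to compound 4 cannot be read, so neither the exchange of these two groups nor hydroxy(sulfo)methyl in place of formyl can be sized: the limit of > 100000 nM in this assay, at which 3 of the 4 values shown sit.

On these data alone, how far apart the compounds at the limit really lie stays open, since compound 2 alone carries a number. Also open, as far as these compounds go, is how a phenyl ring, an amine or a longer chain such as hexyl would read at this position in this assay.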